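A few compounds are considered here, and "the series" means these few. Any claim that something is new, unique, unknown or untested is made for them only; others in the source may bear on it.

Compound 2 `COc1ccc(C(=O)/C=C/c2ccc(-n3ccnc3)cc2)c2c1C=CC(C)(C)O2` is, in a functional assay on SK-OV-3 cells (Homo sapiens) for antiproliferative activity, read by MTT assay, with a stated time of 24 h (on this read-out lower numbers stand for stronger inhibition and higher numbers for weaker inhibition), the higher of the two measured numbers: compound 2 gives 7200 nM, while compound 1 `COc1ccc(C(=O)/C=C/c2ccc(N(C)C)cc2)c2c1C=CC(C)(C)O2` gives 2750 nM. For the measured compounds named here, the one step available, a 2.6-fold higher number from compound 1 to compound 2 (0.42 log units; beyond the scatter), moved the number upward by a modest amount. Compound 3 `COc1ccc(C(=O)/C=C/c2ccc([N+](=O)[O-])cc2)c2c1C=CC(C)(C)O2` differs from compound 2 by nitro in place of 1H-imidazol-1-yl on an aromatic carbon. Going by the values given here, no measured step involves a nitro group, so the earlier step bears only loosely on this change. Compound 3 is therefore expected to land near compound 2, with a step of a 1.2-fold higher number from compound 2 to compound 3 (0.07 log units; within the scatter) lying within the scatter. For compound 3 the estimate is 8500 nM, in the range 3000 nM to 25000 nM.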

Compound 3, half-maximal inhibitory concentration: 3420 nM
For compound 3 the middle estimate is 2.5-fold (0.40 log units) above the measured one; the range from low to high includes it.
By their numbers in this assay, from the lowest: compounds 1 and 3 (each within the scatter of the next); then compound 2.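

In this assay the change to nitro at this position, on an aromatic carbon para to a large group, gives a 2.1-fold lower number from compound 2 to compound 3 (0.32 log units; beyond the scatter) and so lowers the number on leaving 1H-imidazol-1-yl. Dimethylamino is not the only group that does this: nitro in its place gives a 1.2-fold higher number from compound 1 to compound 3 (0.09 log units; within the scatter) and leaves the two groups indistinguishable here. Nothing available accounts for either step. From the compounds shown here alone, whether a primary amine or a carboxylic acid at this position would group with dimethylamino and nitro or with 1H-imidazol-1-yl stays open. So does whether another five-membered aromatic ring, such as pyrazole, would behave like 1H-imidazol-1-yl.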